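From 2,4-dimethylphenyl to 2-chlorophenyl on the shared core

A few compounds are considered here, and "the series" means these few. Any claim that something is new, unique, unknown or untested is made for them only; others in the source may bear on it.

Measured in a functional assay on HeLa cells (Homo sapiens) for antiproliferative activity, read by MTT assay, with a stated time of 72 h; on this read-out lower numbers stand for stronger inhibition and higher numbers for weaker inhibition
Compound 1 `Nc1nc(N)c2cc(CSC(=S)N3CCN(C4CCCCC4)CC3)ccc2n1` gives 5960 nM
Compound 2 `COc1ccc(N2CCN(C(=S)SCc3ccc4nc(N)nc(N)c4c3)CC2)cc1` gives 1660 nM
Compound 3 `Cc1ccc(N2CCN(C(=S)SCc3ccc4nc(N)nc(N)c4c3)CC2)c(C)c1` gives 3190 nM

Compound 3 stands within the scatter of both other compounds, although those two lie further apart. Compound 4 `Nc1nc(N)c2cc(CSC(=S)N3CCN(c4ccccc4Cl)CC3)ccc2n1` carries 2-chlorophenyl in place of 2,4-dimethylphenyl on an amine nitrogen in a ring on the same core. The measured steps that bear on this change swap the same group: a 1.9-fold higher number from compound 2 to compound 3 (0.28 log units; within the scatter) and a 1.9-fold lower number from compound 1 to compound 3 (0.27 log units; within the scatter) both lie within the scatter, while a 3.6-fold lower number from compound 1 to compound 2 (0.56 log units; beyond the scatter) is modest and goes beyond it. Going by the values given here, no measured compound carries 2-chlorophenyl, so no step beyond the scatter is expected in this assay here. The estimated step is a 1.1-fold lower number from compound 3 to compound 4 (0.03 log units; within the scatter) and no more than that. Compound 4 is estimated at 3000 nM with an expected range of 1300 nM to 7000 nM in this read-out.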

Compound 4, half-maximal inhibitory concentration: 4050 nM
Compound 4: the middle estimate sits 1.4-fold (0.13 log units) below what was measured; the measured number falls inside the stated range.
By their numbers in this assay, from the lowest: compounds 2, 3, 4 and 1 (each within the scatter of the next, the first and the last beyond it).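

In this assay, 2-chlorophenyl on the amine nitrogen in a ring cannot be told apart from 2,4-dimethylphenyl, with a 1.3-fold higher number from compound 3 to compound 4 (0.10 log units; within the scatter), or from cyclohexyl, with a 1.5-fold lower number from compound 1 to compound 4 (0.17 log units; within the scatter). Only 4-methoxyphenyl separates from it, with a 2.4-fold higher number from compound 2 to compound 4 (0.39 log units; beyond the scatter), so compound 2 now differs beyond the scatter from two compounds, while compound 3 stays within the scatter of all the others. No evidence is available to explain these numbers.

On these data alone, what a carboxylic acid, an amine or a longer chain would give on this ring nitrogen remains open.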